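A fluorine added to the anilide of compound 2

A few compounds are considered here, and "the series" means these few. Any claim that something is new, unique, unknown or untested is made for them only; others in the source may bear on it.

In a functional assay on HL-60 cells (Homo sapiens) for cytotoxicity, read by MTT assay, with a stated time of 24 h (a lower number here means a stronger inhibitor, a higher number a weaker inhibitor), compound 1 `CCCCCCCCCCn1cc(Cn2nc(N)c3c(C(F)(F)F)cc(-c4ccccc4)nc32)nn1` gives 29.9 ug/mL, and compound 2 `Nc1nn(Cc2cn(CC(=O)Nc3ccccc3)nn2)c2nc(-c3ccccc3)cc(C(F)(F)F)c12` gives 96.3 ug/mL. The only measured step, a 3.2-fold higher number from compound 1 to compound 2 (0.51 log units; beyond the scatter), sets compound 2 as the weaker of the two compounds; it stands at the highest number of the two shown, and the nearest measured neighbour is compound 1, a modest gap that lies beyond the scatter.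

Compound 3 `Nc1nn(Cc2cn(CC(=O)Nc3cccc(F)c3)nn2)c2nc(-c3ccccc3)cc(C(F)(F)F)c12` differs from compound 2 by a single change: fluoro in place of hydrogen on an aromatic carbon, so that the phenylcarbamoyl becomes a (3-fluorophenyl)carbamoyl. For the measured compounds named here, no measured pair in this set touches the aromatic ring of the anilide; the one known step concerns the exchange of nonyl for phenylcarbamoyl and does not speak to a fluorine on that ring. With nothing bearing on it, compound 3 is expected to stay close to compound 2, a step of a 1.1-fold lower number from compound 2 to compound 3 (0.03 log units; within the scatter) in this assay. The estimate for compound 3 in this assay is 90 ug/mL, expected to fall between 45 ug/mL and 180 ug/mL.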

Compound 3, half-maximal inhibitory concentration: 63.9 ug/mL
Compound 3: the middle estimate sits 1.4-fold (0.15 log units) above what was measured; measured number inside the range.
By their numbers in this assay, from the lowest: compound 1; then compounds 3 and 2 (each within the scatter of the next).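

At this aromatic carbon, the first change made on the anilide ring, fluoro in place of hydrogen gives a 1.5-fold lower number from compound 2 to compound 3 (0.18 log units; within the scatter), so in this assay compound 2 and compound 3 cannot be told apart. The nonyl chain of compound 1 still holds a lower number than the fluorinated anilide, with a 2.1-fold higher number from compound 1 to compound 3 (0.33 log units; beyond the scatter), so the gap between the chain and the anilide remains beyond the scatter with fluoro in place. No measurement at hand offers an explanation for either step.

As far as these compounds go, what a chlorine, a methoxy group or a nitrile on this same aromatic carbon would give remains open. Also open, from the compounds shown here alone, is how a carboxylic acid or an amine in place of the anilide would compare with compound 1 and compound 2.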